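The source may report more compounds than this note shows. Statements on the series, on what has been measured and on what is new or still open speak of the compounds shown alone.

Of the compounds shown here, two of this kind have been measured in an assay on isolated protein for inhibition of Phenylethanolamine N-methyltransferase (Bos taurus); a higher number here means a weaker inhibitor, a lower number a stronger inhibitor. Compound 1, with the structure `NCC(O)C1CCCCCC1`, gives 8000 nM. Compound 2, with the structure `O=CC1CCCCCCCC1`, gives 6000 nM. Compound 2 thus holds the lower of the two numbers, but the gap to compound 1 lies within the usual scatter, so the two values cannot be told apart.

Compound 3, with the structure `NCC(O)C1CCCCCCCC1`, has not yet been measured. It differs from compound 2 in one place: 2-amino-1-hydroxyethyl in place of formyl on a saturated ring carbon. The same 2-amino-1-hydroxyethyl group already appears in compound 1 on a smaller ring, where compound 1 gives 8000 nM, a value indistinguishable from that of compound 2. On this basis the step from compound 2 to compound 3 is expected to be small, a 1.2-fold higher number from compound 2 to compound 3 (0.07 log units; within the scatter), with no direction beyond the scatter. For compound 3 the estimate in this assay is 7000 nM, with a range from 2500 nM to 20000 nM.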

Compound 3, half-maximal inhibitory concentration: 6000 nM
For compound 3 the middle estimate is 1.2-fold (0.07 log units) above the measured one; measured number inside the range.
By their numbers in this assay, from the lowest: compounds 2, 3 and 1 (each within the scatter of the next).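

In this assay, going by these compounds alone, exchanging formyl for 2-amino-1-hydroxyethyl on a saturated ring carbon of the nine-membered ring gives no change at the digits printed from compound 2 to compound 3 (within the scatter), so this is the first direct reading at this position. The entering group has more heavy atoms than formyl and carries hydrogen-bond donors, which formyl lacks, yet this exchange leaves the inhibition number in the same place. Nothing available explains why the two groups read alike.

Going by these compounds, it remains open whether a different group on this ring carbon, such as an aminomethyl group, a carboxylic acid or a longer carbon chain, would move the number beyond the scatter. The compounds shown also do not separate the amine from the hydroxyl within 2-amino-1-hydroxyethyl, so neither part can be judged alone.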